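A new phenyl group on a heavily protein-bound compound

This account rests on a few compounds, and the source may have more. Where it says the series, first, only, none or still open, it means among the compounds named here.

Measured in an ADME assay on a cell-free system (plasma, Homo sapiens) for protein binding 
- compound 1 `CNc1[nH]c(=O)n(O)c(=O)c1C(=O)NCc1ccccc1` gives 99.2% 
- compound 2 `CCNc1[nH]c(=O)n(O)c(=O)c1C(=O)NCc1ccccc1` gives 99.1% 

Compound 2 stands level with compound 1 within the scatter. For the measured compounds named here, the only measured step is a 1.1-fold higher unbound fraction from compound 1 to compound 2 (0.05 log units; within the scatter) and it lies at a different place, so it offers little guidance here. Going by the values given here, compound 3 `CCNc1[nH]c(=O)n(O)c(=O)c1C(=O)NCc1cccc(Cl)c1F` differs from compound 2 by 3-chloro-2-fluorophenyl in place of phenyl on a saturated chain carbon bound to an amide-type nitrogen and no measured step covers this change. With compound 2 at 99.1% the read-out has little room left, so a small rise in binding is expected. The estimated step is a 2.3-fold lower unbound fraction from compound 2 to compound 3 (0.35 log units; beyond the scatter) in this assay with real uncertainty. Compound 3 is expected at 99.6% within an estimated range of 99.1% to 99.9% for now.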

Compound 3, plasma protein binding: 98.4%
Compound 3: the middle estimate sits 4.0-fold (0.60 log units) (unbound fraction) below what was measured; the measured number lies below the stated range.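

In this assay, putting 3-chloro-2-fluorophenyl in place of phenyl on the saturated chain carbon bound to an amide-type nitrogen gives a 1.8-fold higher unbound fraction from compound 2 to compound 3 (0.25 log units; within the scatter) and so leaves this read-out level within the scatter. The earlier compounds shown here differed only in the chain on the nitrogen on the aromatic ring, so this is the only view of the phenyl end, and it shows that this end accepts a fluorine and a chlorine without a step beyond the scatter. Still open, as far as these compounds go, is whether a carboxylic acid or an amine on this phenyl ring would shift the unbound fraction beyond the scatter. No measurement shown here explains the size of this step.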